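The compounds below may be only part of what the source reports. "The series", "measured", "known", "first", "only" and "open" are said of these compounds alone.

In a functional assay on the whole organism for antagonist activity, with Mus musculus as the target (a higher number here means that more compound is needed for the effect, a lower number that less compound is needed), compound 2, `CC(=O)NCC#CCn1ccnc1`, gives > 100 mg/kg. That value is a limit of the assay and not a number, so compound 2 has no exact position on the scale.

In this assay compound 1, `CC(=O)N(C)C(C)C#CCn1ccnc1`, gives > 100 mg/kg, which is also a limit and not a number.

Compound 3, `CC(=O)N(C)CC#CCn1ccnc1`, differs from compound 2 in one place: methyl in place of hydrogen on an amide-type nitrogen. Within the data shown here, neither measured compound gives a number, so no measured step shows how large the effect of such a change might be. The only starting point for the expectation is compound 2 at > 100 mg/kg, which is a limit.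

The step that the limit leaves unreadable from compound 2 to compound 3 is expected to stay within the usual scatter, with no clear direction. Compound 3 is estimated at 150 mg/kg, with an expected range from 60 mg/kg to 300 mg/kg. The most likely outcome is that the assay again reports only a limit rather than a number.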

Compound 3, dose for half-maximal effect: > 100 mg/kg
Compound 3 ended at the assay's limit; the forecaster's own chance of this, stated with the estimate: 75%; the middle value is on the limit's open side.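

No step among compound 1, compound 2 and compound 3 can be read in this assay, because all three end at the same limit of the assay: the limit of > 100 mg/kg in this assay, at which 3 of the 3 values shown sit.

The compounds shown leave open whether methyl in place of hydrogen on an amide-type nitrogen changes the dose needed, and what exact dose any of the three requires.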